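Fluorophenyl isomers: from compound 2 to compound 3

The compounds below may be only part of what the source reports. "The series", "measured", "known", "first", "only" and "open" are said of these compounds alone.

Measured in an assay on microsomes for inhibition of 3-hydroxy-3-methylglutaryl-coenzyme A reductase (Rattus norvegicus); a lower number here means a stronger inhibitor, a higher number a weaker inhibitor:
Compound 1, `CC(C)c1sc(-c2ccccc2)c(-c2cccc(C(F)(F)F)c2)c1/C=C/[C@@H](O)C[C@@H](O)CC(=O)O`, gives 2980 nM.
Compound 2, `CC(C)c1sc(-c2ccccc2)c(-c2ccccc2F)c1/C=C/[C@@H](O)C[C@@H](O)CC(=O)O`, gives 233 nM.

Going by the values given here, compound 2 holds the lowest number of the two, and its only neighbour is compound 1, from which it is separated by the step of a 13-fold lower number from compound 1 to compound 2 (1.11 log units; beyond the scatter). Among the compounds with values here, that step exchanges one aryl group for a different one, and it is the only step measured so far.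

Compound 3, `CC(C)c1sc(-c2ccccc2)c(-c2ccc(F)cc2)c1/C=C/[C@@H](O)C[C@@H](O)CC(=O)O`, is not yet measured. Its change from compound 2 is 4-fluorophenyl in place of 2-fluorophenyl on an aromatic carbon. The same atoms are kept and only joined differently: the fluorine is moved to another carbon of the phenyl ring. Within the data shown here, no measured step bears on a change of this kind; the one measured step swaps a whole group rather than relocating one atom, and gives no guide to direction. The expectation for compound 3 is therefore a number close to that of compound 2, with no step beyond the scatter, so a 1.3-fold higher number from compound 2 to compound 3 (0.11 log units; within the scatter) is expected. Compound 3 is estimated at 300 nM in this assay, within 100 nM to 1000 nM.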

Compound 3, half-maximal inhibitory concentration: 4.4 nM
Compound 3: middle estimate off by 68-fold (1.83 log units), on the high side, outside the stated range (below it).
By their numbers in this assay, from the lowest: compound 3; then compound 2; then compound 1.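

In this assay, moving one fluorine, with 4-fluorophenyl in place of 2-fluorophenyl, gives a 53-fold lower number from compound 2 to compound 3 (1.72 log units; beyond the scatter) and makes compound 3 the strongest inhibitor of the three, so this place on the five-membered aromatic ring with 1 sulfur separates two groups built from the same atoms. Relocating that one atom moves the number further than the whole-group exchange in a 13-fold lower number from compound 1 to compound 2 (1.11 log units; beyond the scatter) did, and the exchange of 3-(trifluoromethyl)phenyl for 4-fluorophenyl now spans a 680-fold lower number from compound 1 to compound 3 (2.83 log units; beyond the scatter) across the series. No measurement available here explains why the location of the fluorine matters so much.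

Three compounds cannot separate the contribution of the fluorine itself from that of a substituent at the 4-position of this phenyl ring, and a plain phenyl group at this place would provide the missing reference point. As far as these compounds go, it also remains open whether 4-chlorophenyl, 4-methylphenyl or 4-methoxyphenyl would keep a number close to that of compound 3 or lose most of the gain.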